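Tert-butyl benzamide series: ethoxy in place of carbamoyl

This account rests on a few compounds, and the source may have more. Where it says the series, first, only, none or still open, it means among the compounds named here.

Compound 1 `CC(C)(C)c1ccc(C(=O)NCc2ccc(C(N)=O)cc2)cc1` is one of two measured members of this series. In an assay on HeLa cells with Bile acid receptor (Homo sapiens) as the target, read by a luciferase reporter, with a stated time of 24 h (a higher number here means that more compound is needed for the effect, a lower number that less compound is needed), compound 1 gives 3800 nM, the lowest of the two numbers on hand. Going by the values given here, the only other measured compound, compound 2 `CC(C)(C)c1ccc(C(=O)NCc2ccc(C(=O)O)cc2Cl)cc1`, gives 7500 nM in this assay; the two numbers lie within the usual scatter of each other, and compound 2 differs from compound 1 in more than one place, so no single step can be read from the pair.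

Compound 3 `CCOc1ccc(CNC(=O)c2ccc(C(C)(C)C)cc2)cc1` has not yet been measured in this assay. It differs from compound 1 as follows: ethoxy in place of carbamoyl on an aromatic carbon. The group that leaves carries a hydrogen-bond donor; the ethoxy that enters carries none, on the same aromatic carbon, para to a large group.

Among the compounds with values here, with no single-change step measured, the size of the step from compound 1 to compound 3 cannot be anchored. The expectation is a step of a 1.3-fold higher number from compound 1 to compound 3 (0.12 log units; within the scatter), not clearly beyond the scatter in either direction. Compound 3 is therefore estimated at 5000 nM in this assay, with a range of 1500 nM to 20000 nM.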

Compound 3, half-maximal effective concentration: 160 nM
Compound 3: middle estimate off by 31-fold (1.49 log units), on the high side; the measured number lies below the stated range.
By their numbers in this assay, from the lowest: compound 3; then compounds 1 and 2 (each within the scatter of the next).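

In this assay, the aromatic carbon para to a large group responds strongly to the group it carries: ethoxy in place of carbamoyl gives a 24-fold lower number from compound 1 to compound 3 (1.38 log units; beyond the scatter) in a single change, something the earlier pair could not show because its members differ in more than one place. The two groups have the same count of heavy atoms and of hydrogen-bond acceptors, so the step comes with a change of group type at constant heavy-atom count, with the hydrogen-bond donor and the double bond of carbamoyl gone and a second carbon present in ethoxy. Nothing on hand establishes which of these differences accounts for the step.

From the compounds shown here alone, it remains open whether the lower number depends on the oxygen of the ethoxy or on its two-carbon chain, a question that methoxy, propoxy or a plain ethyl at this carbon would help to separate. Also open, going by these compounds, is how an amine or a carboxylic acid on the same carbon would compare, with the rest of the core of compound 1 unchanged.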